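From trifluoromethyl to methyl: expectations for compound 4

This account rests on a few compounds, and the source may have more. Where it says the series, first, only, none or still open, it means among the compounds named here.

In a functional assay on LOX IMVI cells (Homo sapiens) for cytotoxicity, read by MTT assay, with a stated time of 24 h (a higher number here means a weaker inhibitor, a lower number a stronger inhibitor), compound 1 (`O=S(=O)(NCCCNc1nccc(-c2[nH]c(-c3ccccc3)nc2-c2ccc(F)c(O)c2)n1)c1ccc(Cl)cc1`) gives 14200 nM and compound 2 (`O=S(=O)(NCCCNc1nccc(-c2[nH]c(-c3ccccc3)nc2-c2ccc(F)c(O)c2)n1)c1ccc(Br)cc1`) gives 5660 nM. Compound 3 (`O=S(=O)(NCCCNc1nccc(-c2[nH]c(-c3ccccc3)nc2-c2ccc(F)c(O)c2)n1)c1ccc(C(F)(F)F)cc1`) gives 2450 nM and holds the lowest number of the three. Compound 4 (`Cc1ccc(S(=O)(=O)NCCCNc2nccc(-c3[nH]c(-c4ccccc4)nc3-c3ccc(F)c(O)c3)n2)cc1`) has not been measured. It carries methyl in place of trifluoromethyl on an aromatic carbon, para to a large group (methyl in place of trifluoromethyl on an aromatic carbon). Within the data shown here, no measured compound carries methyl, so the read-across is indirect. Two measured steps end at trifluoromethyl: a 2.3-fold lower number from compound 2 to compound 3 (0.36 log units; beyond the scatter) and a 5.8-fold lower number from compound 1 to compound 3 (0.76 log units; beyond the scatter). Both are modest, and a 2.5-fold lower number from compound 1 to compound 2 (0.40 log units; beyond the scatter) is of similar size. Leaving trifluoromethyl is therefore expected to raise the number by a modest amount, since compound 2 sits only a 2.3-fold lower number from compound 2 to compound 3 (0.36 log units; beyond the scatter) away and compound 1 marks the far end of the series. The step expected is a 2.4-fold higher number from compound 3 to compound 4 (0.39 log units; beyond the scatter) as an estimate with real uncertainty. For compound 4 the estimated value is 6000 nM with 2200 nM to 15000 nM as the expected range.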

Compound 4, half-maximal inhibitory concentration: 26300 nM
Compound 4: the middle estimate sits 4.4-fold (0.64 log units) below what was measured; the whole stated range lies below it.
By their numbers in this assay, from the lowest: compound 3; then compound 2; then compounds 1 and 4 (each within the scatter of the next).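

In this assay, among these compounds, this position, para to a large group, gives a wider spread than the earlier compounds showed: an 11-fold higher number from compound 3 to compound 4 (1.03 log units; beyond the scatter) is the first large step, whereas every earlier step was modest. Methyl also falls well away from bromo, with a 4.6-fold higher number from compound 2 to compound 4 (0.67 log units; beyond the scatter), while a 1.9-fold higher number from compound 1 to compound 4 (0.27 log units; within the scatter) stays within the scatter, so methyl and chloro cannot be told apart here and trifluoromethyl remains the group with the lowest number of the four. No measurement is available that accounts for the size of the change from trifluoromethyl to methyl.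

Still open, on these data alone, is how a plain hydrogen, a methoxy group, a nitrile or an amine would rank at this position. Also open, as far as these compounds go, is whether the gap between trifluoromethyl and methyl would persist with a longer chain in the linker.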